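From Chloro to Fluoro: An Untested Swap

The source may hold more compounds than are shown below. What is called first, only, known or untested is meant among the compounds shown, and "the series" means these compounds.

In a functional assay on HeLa cells (Homo sapiens) for cytotoxicity, read by XTT assay, with a stated time of 24 h (on this read-out lower numbers stand for stronger inhibition and higher numbers for weaker inhibition), compound 2 `Cc1cc(O)c2c(c1Cl)C(=O)C=CC2=O` gives 13500 nM and compound 1 `CC(=O)Oc1cc(C)c(Cl)c2c1C(=O)C=CC2=O` gives 26200 nM, two values within the scatter of each other. Among the compounds with values here, the only measured step, a 1.9-fold lower number from compound 1 to compound 2 (0.29 log units; within the scatter), puts hydrogen in place of acetyl on an oxygen, so it concerns a different group. Compound 3 `Cc1cc(O)c2c(c1F)C(=O)C=CC2=O` differs from compound 2 in one place: fluoro in place of chloro on an aromatic carbon. Within the data shown here, no measured step covers this change. No step beyond the scatter is therefore expected in this assay, and the estimated step is a 1.1-fold higher number from compound 2 to compound 3 (0.05 log units; within the scatter). For compound 3 the estimated value is 15000 nM, with an expected range from 6000 nM to 38000 nM.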

Compound 3, half-maximal inhibitory concentration: 10200 nM
For compound 3 the middle estimate is 1.5-fold (0.17 log units) above the measured one; the range from low to high includes it.
By their numbers in this assay, from the lowest: compounds 3, 2 and 1 (each within the scatter of the next, the first and the last beyond it).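

In this assay fluoro in place of chloro, on the aromatic carbon para to a hydroxy group, gives a 1.3-fold lower number from compound 2 to compound 3 (0.12 log units; within the scatter) and so brings no difference that can be told from the scatter. Compound 1 and compound 2 both carry chloro here, so they said nothing about this position; now two different halogens on it give values that cannot be told apart.

On these data alone, whether an amine, a methoxy group or a trifluoromethyl group on this carbon would read the same stays open. Nothing measured here speaks to why chloro and fluoro read alike.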